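Aryl variation on a nitroimidazole-oxadiazole thioether series

The compounds below may be only part of what the source reports. "The series", "measured", "known", "first", "only" and "open" are said of these compounds alone.

Three compounds share one core and differ only in the aryl group on the five-membered ring. Compound 1 `Cc1ncc([N+](=O)[O-])n1CCSc1nnc(-c2ccc(N)cc2)o1` carries 4-aminophenyl and in a functional assay on SGC-7901 cells (Homo sapiens) for cytotoxicity, read by MTT assay, with a stated time of 48 h (a higher number here means a weaker inhibitor, a lower number a stronger inhibitor), compound 1 gives 31700 nM. Compound 2 `Cc1ncc([N+](=O)[O-])n1CCSc1nnc(-c2ccccc2F)o1` carries 2-fluorophenyl and in this assay compound 2 gives 33700 nM. Compound 3 `Cc1cccc(-c2nnc(SCCn3c([N+](=O)[O-])cnc3C)o2)c1O` carries 2-hydroxy-3-methylphenyl and in this assay compound 3 gives 35900 nM. The three numbers lie within the scatter of one another: a 1.1-fold higher number from compound 1 to compound 2 (0.03 log units; within the scatter), a 1.1-fold higher number from compound 1 to compound 3 (0.05 log units; within the scatter) and a 1.1-fold higher number from compound 2 to compound 3 (0.03 log units; within the scatter) are all small.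

Compound 4 `Cc1ncc([N+](=O)[O-])n1CCSc1nnc(-c2ccnc(Cl)c2)o1` takes the same core with a different aryl group. 2-chloropyridin-4-yl in place of 2-hydroxy-3-methylphenyl on an aromatic carbon

For the measured compounds named here, the steps that bear on this change are the aryl swaps already seen, a 1.1-fold higher number from compound 1 to compound 3 (0.05 log units; within the scatter) and a 1.1-fold higher number from compound 2 to compound 3 (0.03 log units; within the scatter), each within the scatter. Three aryl groups of different character gave indistinguishable numbers, so no step beyond the scatter is expected for compound 4 in this assay, and the expected step is a 1.1-fold lower number from compound 3 to compound 4 (0.02 log units; within the scatter). The estimated value for compound 4 in this assay is 34000 nM, with a range from 17000 nM to 70000 nM. The evidence for this guess is limited to three compounds and one aryl position.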

Compound 4, half-maximal inhibitory concentration: 32300 nM
Compound 4: the middle estimate sits 1.1-fold (0.02 log units) above what was measured; the measured number falls inside the stated range.
By their numbers in this assay, from the lowest: compounds 1, 4, 2 and 3 (each within the scatter of the next).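

Compound 4 is the only one of the four whose aryl group has a hetero atom in the six-membered aromatic ring and the only one that carries chlorine, yet in this assay this change stays inside the scatter against all three earlier aryl groups (a 1.1-fold lower number from compound 3 to compound 4 (0.05 log units; within the scatter)) (a 1.0-fold lower number from compound 2 to compound 4 (0.02 log units; within the scatter)) (a 1.0-fold higher number from compound 1 to compound 4 (0.01 log units; within the scatter)). Against compound 3, the change also goes from 1 hydrogen-bond donor to 0 donors on the aryl group, and no step beyond the scatter comes with it, so the insensitivity at this position now extends from phenyl groups to a chloropyridine. No measurement bearing on the reason for this flat response is available.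

All four values remain within the scatter of one another, so no aryl group shown marks out a feature of this position that moves the number in this assay. Going by these compounds, whether a saturated ring such as cyclohexyl, a carboxylic acid on the phenyl ring or a longer chain between the shared core and the aryl group would produce a step beyond the scatter stays open.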